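Aryl variation on the triazole nitrogen of the shared core

The compounds below may be only part of what the source reports. "The series", "measured", "known", "first", "only" and "open" are said of these compounds alone.

Among the measured compounds shown here, compound 1 `Cc1ccccc1-n1cc(-c2ccc(/C=C3\C(=O)Nc4ccccc43)cc2)nn1` holds the only numerical value: in a functional assay on HT-29 cells (Homo sapiens) for inhibition, read by CCK-8 assay, with a stated time of 24 h (on this read-out higher numbers stand for weaker inhibition and lower numbers for stronger inhibition), compound 1 gives 8710 nM. Compound 2 `O=C1Nc2ccccc2/C1=C/c1ccc(-c2cn(-c3ccccc3Cl)nn2)cc1` sits at a limit of the assay rather than at a number, (the limit of > 20000 nM in this assay, at which 1 of the 2 values shown sits). In this assay compound 2 gives > 20000 nM, a limit only. For the measured compounds named here, the single measured step, an at least 2.2-fold higher number from compound 1 to compound 2 (0.36 log units; beyond the scatter), is the only guide to what exchanging the 2-methylphenyl of compound 1 does. Compound 3 `N#Cc1cccc(-n2cc(-c3ccc(/C=C4\C(=O)Nc5ccccc54)cc3)nn2)c1` differs from compound 1 by 3-cyanophenyl in place of 2-methylphenyl on an aromatic nitrogen. Going by the values given here, no measured step covers a 3-cyanophenyl or a nitrile, and the one exchange made on this group weakened inhibition to the point of a limit. A step of a 1.6-fold higher number from compound 1 to compound 3 (0.21 log units; within the scatter) toward weaker inhibition is therefore expected, of modest size, with a real chance that only a limit is returned. Compound 3 is estimated at 14000 nM, within the range 5000 nM to 35000 nM.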

Compound 3, half-maximal inhibitory concentration: > 20000 nM
Compound 3: a limit, no number (the forecaster's own chance of this, stated with the estimate: 35%); at least 1.4-fold (0.15 log units) between middle value and limit.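

In this assay, 3-cyanophenyl in place of 2-methylphenyl on the aromatic nitrogen gives an at least 2.2-fold higher number from compound 1 to compound 3 (0.36 log units; beyond the scatter), so a second replacement, this one carrying a nitrile, also shifts beyond the scatter toward weaker inhibition. Of the three aryl groups shown on this nitrogen, only the 2-methylphenyl of compound 1 returns a number, and the other two values are limits: the limit of > 20000 nM in this assay, at which 2 of the 3 values shown sit. The step between compound 2 and compound 3 cannot be read, and the 2-chlorophenyl and 3-cyanophenyl groups cannot be ranked.

Compound 1 and compound 3 differ in both the substituent and its place on the ring, and the compounds shown do not separate the two. From the compounds shown here alone, whether an amine, a carboxylic acid or a longer chain on this aryl ring would give a lower number than compound 1 remains open.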